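A Growth Inhibitor Near the Top of Its Scale

The source may report more compounds than this note shows. Statements on the series, on what has been measured and on what is new or still open speak of the compounds shown alone.

In a functional assay on SiHa cells (Homo sapiens) for inhibition, read by CCK-8 assay, with a stated time of 72 h, tested at 10 uM (a lower number here means less inhibition of growth, a higher number more inhibition of growth at the concentration tested), compound 1 `CN(C)C(=O)c1cc2cnc(Nc3ccc(NC(=O)C4(C(=O)Nc5cccc(O)c5)CC4)cc3)nc2n1C1CCCC1` gives 75.7% and compound 2 `CN(C)C(=O)c1cc2cnc(Nc3ccc(NC(=O)C4(C(=O)Nc5cccc(Cl)c5)CC4)cc3)nc2n1C1CCCC1` gives 97.3%, the higher of the two numbers, leaving little room for any further rise. Compound 3 `CN(C)C(=O)c1cc2cnc(Nc3ccc(NC(=O)C4(C(=O)Nc5ccc(Cl)c(C(F)(F)F)c5)CC4)cc3)nc2n1C1CCCC1` has 4-chloro-3-(trifluoromethyl)phenyl in place of 3-chlorophenyl on an amide-type nitrogen. Among the compounds with values here, only one measured step bears on this change, and only loosely. That step, a number 21.6 percentage points higher from compound 1 to compound 2 (beyond the scatter), came with chloro in place of hydroxy on an aromatic carbon. Within the data shown here, the entering group keeps a chloro, but no measured compound carries a trifluoromethyl, so the data do not test that addition. The expected result is therefore a small move downward, with no real change beyond the scatter, and the estimated step is a number 3.3 percentage points lower from compound 2 to compound 3 (within the scatter). For compound 3 the estimate is 94%, with an expected range of 80% to 101%.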

Compound 3, percent growth inhibition at one concentration: 61.1%
The estimate for compound 3 lay 32.9 percentage points above the measured number; the whole stated range lies above it.
By their numbers in this assay, from the lowest: compound 3; then compound 1; then compound 2.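

At this amide-type nitrogen, the larger aryl group costs much more than the earlier chloro-for-hydroxy step gave: this assay shows a number 36.2 percentage points lower from compound 2 to compound 3 (beyond the scatter), so a ring chloro does not by itself keep growth inhibition near the top of the scale. The same group also ends below the hydroxy-bearing compound, with a number 14.6 percentage points lower from compound 1 to compound 3 (beyond the scatter), which makes 4-chloro-3-(trifluoromethyl)phenyl the poorest of the three aryl groups shown here at this nitrogen. Nothing available explains why the number falls at this position.

Because the trifluoromethyl enters here together with a change in the chloro's placing, the compounds shown cannot separate the contribution of either one. They also leave open how a methoxy, a methyl or an amine on this phenyl ring would read in this assay, and whether any such ring would stay near the value of compound 2 at 97.3%.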